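The source may hold more compounds than are shown below. What is called first, only, known or untested is meant among the compounds shown, and "the series" means these compounds.

Compound 1 `CCCC(=O)Nc1c(C(O)(C(F)(F)F)C(F)(F)F)ccc2ccccc12`: 92%
Compound 2 `O=C(Nc1c(C(O)(C(F)(F)F)C(F)(F)F)ccc2ccccc12)c1cccc(Cl)c1`: 84%
Compound 3 `N#Cc1cccc(C(=O)Nc2c(C(O)(C(F)(F)F)C(F)(F)F)ccc3ccccc23)c1`: 96%

Going by the values given here, in a functional assay (Sus scrofa) with sulfonylurea receptors; K-ATP channels (Homo sapiens) as the target (a higher number here means a larger maximal response, a lower number a smaller maximal response), compound 3 has the highest of the three numbers measured so far. Its nearest neighbour is compound 1, and that gap, a number 4 percentage points higher from compound 1 to compound 3 (within the scatter), is within the scatter, so the two cannot be told apart. The furthest is compound 2, with a gap of a number 12 percentage points higher from compound 2 to compound 3 (beyond the scatter), a modest but real difference.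

Compound 4 `O=C(Nc1c(C(O)(C(F)(F)F)C(F)(F)F)ccc2ccccc12)c1ccco1` is not yet measured. It differs from compound 3 in one place: furan-2-yl in place of 3-cyanophenyl on a carbonyl carbon. The group on the carbonyl carbon that sits next to the amide-type nitrogen is exchanged.

Two earlier steps also swapped the group on that carbonyl carbon, and both stayed within the scatter: a number 8 percentage points lower from compound 1 to compound 2 (within the scatter) and a number 4 percentage points higher from compound 1 to compound 3 (within the scatter). Among the compounds with values here, the only step beyond the scatter, a number 12 percentage points higher from compound 2 to compound 3 (beyond the scatter), came from swapping a substituent on the ring rather than the whole ring. Within the data shown here, no compound with a furan-2-yl group has been measured, so the new group has no direct precedent here. Given that the larger exchanges on this carbonyl carbon moved little, the expected step of a number 8 percentage points lower from compound 3 to compound 4 (within the scatter) is small, most likely within the scatter. Compound 4 is therefore estimated at 88%, with a range of 74% to 100%.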

Compound 4, largest response reached (reported as efficacy), in percent of the reference or control that the assay uses: 96%
Estimate against measurement, compound 4: 8 percentage points below; measured number inside the range.
By their numbers in this assay, from the lowest: compounds 2, 1, 3 and 4 (each within the scatter of the next, the first and the last beyond it).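

In this assay, furan-2-yl brings a five-membered aromatic ring with a hetero atom onto this carbonyl carbon, and replacing 3-cyanophenyl with it gives no change at the digits printed from compound 3 to compound 4 (within the scatter), so this position tolerates a ring of 5 heavy atoms in place of one of 8 without a readable change. Against the 3-chlorophenyl compound, the same group gives a number 12 percentage points higher from compound 2 to compound 4 (beyond the scatter), matching the earlier a number 12 percentage points higher from compound 2 to compound 3 (beyond the scatter), so compound 2 stands apart from both compound 3 and compound 4, while a number 4 percentage points higher from compound 1 to compound 4 (within the scatter) leaves the propyl compound and the furan compound indistinguishable. No measurement available here explains why these groups give the responses they do.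

Going by these compounds, the groups compared on this carbonyl carbon are only a propyl chain and three aromatic rings, and the steps among them are modest at most, so the effect of an amine, a carboxylic acid or a longer chain here remains open. On these data alone, it also remains open whether a thiophene or pyridine ring, or a change to the shared core, would keep the response in this assay at this level.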